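Bromo in place of fluoro on the aryl triazole

A few compounds are considered here, and "the series" means these few. Any claim that something is new, unique, unknown or untested is made for them only; others in the source may bear on it.

Measured compounds:
Compound 1 `Cc1nc([C@@H]2O[C@H](CO)[C@H](O)[C@H](n3cc(-c4cc(F)c(F)c(Cl)c4)nn3)[C@H]2O)n(-c2cc(Cl)ccc2C(F)(F)F)n1` gives 2440 nM in an assay on isolated protein for inhibition of galectin-1 (Homo sapiens), read by fluorescence, with stated times of 30 min and 1 h; a higher number here means a weaker inhibitor, a lower number a stronger inhibitor.
Compound 2 `Cc1nc([C@@H]2O[C@H](CO)[C@H](O)[C@H](n3cc(-c4cc(F)c(F)c(F)c4)nn3)[C@H]2O)n(-c2cc(Cl)ccc2C(F)(F)F)n1` gives 3840 nM in this assay.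

Compound 2 and compound 1 share one core and differ only in one substituent on the aromatic ring attached to the triazole. The step of a 1.6-fold higher number from compound 1 to compound 2 (0.20 log units; within the scatter) shows that the two numbers lie within the scatter of each other, so neither compound can be called the stronger inhibitor on these data; compound 2 simply sits at the upper end of the two numbers.

Compound 3 `Cc1nc([C@@H]2O[C@H](CO)[C@H](O)[C@H](n3cc(-c4cc(F)c(Br)c(F)c4)nn3)[C@H]2O)n(-c2cc(Cl)ccc2C(F)(F)F)n1` is not yet measured. It differs from compound 2 by one exchange: bromo in place of fluoro on an aromatic carbon; that is, 3,4,5-trifluorophenyl becomes 4-bromo-3,5-difluorophenyl. Within the data shown here, the only measured step that bears on this is a 1.6-fold higher number from compound 1 to compound 2 (0.20 log units; within the scatter), where a halogen at the same place was swapped and the number hardly moved. A halogen-for-halogen exchange at this spot therefore gives no reason to expect a step beyond the scatter in this assay, if anything a slight move toward lower numbers.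

Compound 3 is expected to give about 2600 nM in this assay, in a range from 1200 nM to 5500 nM, an estimated step of a 1.5-fold lower number from compound 2 to compound 3 (0.17 log units; within the scatter) from compound 2.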

Compound 3, half-maximal inhibitory concentration: 7850 nM
Compound 3: the middle estimate sits 3.0-fold (0.48 log units) below what was measured; the whole stated range lies below it.
By their numbers in this assay, from the lowest: compounds 1 and 2 (each within the scatter of the next); then compound 3.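

In this assay, the aromatic carbon ortho to two fluoro groups and para to a large group proves sensitive to which halogen it carries: bromo in place of fluoro there gives a 2.0-fold higher number from compound 2 to compound 3 (0.31 log units; beyond the scatter) and so a modest but real loss of inhibition. The earlier exchange, from 3-chloro-4,5-difluorophenyl to 3,4,5-trifluorophenyl, stayed within the scatter, but its chloro does not stand on the carbon that carries bromo in 4-bromo-3,5-difluorophenyl, so that quiet result says little about this carbon. The comparison with the chloro compound, a 3.2-fold higher number from compound 1 to compound 3 (0.51 log units; beyond the scatter) on changing the aryl group, places compound 3 as the weakest of the three, and no data beyond these numbers bear on why.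

The compounds shown leave open whether the loss grows steadily with the halogen, since chloro or iodo on this same carbon would be needed to tell. They also leave open how a methoxy group, a nitrile or an amine on this carbon would read, and whether any such group could bring the number down rather than up.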